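From Nitro to Chloro: Expected Dose for Compound 3

The source may hold more compounds than are shown below. What is called first, only, known or untested is meant among the compounds shown, and "the series" means these compounds.

Compound 1, `O=C(N/N=C/c1ccccc1[N+](=O)[O-])Nc1cccc2ccccc12`: 300 mg/kg
Compound 2, `COc1ccc(OC)c(/C=N/NC(=O)Nc2cccc3ccccc23)c1`: 300 mg/kg

In a functional assay on the whole organism (strain Swiss albino) with Mus musculus as the target, with a stated time of 0.5 h (a lower number here means that less compound is needed, a higher number that more compound is needed for the effect), compound 1 gives 300 mg/kg, level with compound 2, which gives 300 mg/kg in this assay. Compound 3, `O=C(N/N=C/c1ccccc1Cl)Nc1cccc2ccccc12`, differs from compound 1 by chloro in place of nitro on an aromatic carbon. Among the measured compounds shown here, no pair of measured compounds shows what this exchange does to the dose, so the two values give no direction to follow. The step of no change at the digits printed from compound 1 to compound 3 (within the scatter) is expected to stay within the scatter of this assay. Compound 3 is therefore estimated at 300 mg/kg, with a range from 100 mg/kg to 600 mg/kg.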

Compound 3, minimum effective dose: 300 mg/kg
For compound 3 middle estimate and measured number coincide at the digits printed; the measured number falls inside the stated range.
By their numbers in this assay, from the lowest: compounds 1, 2 and 3 (each within the scatter of the next).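

In this assay, among the compounds shown here, chloro in place of nitro on this aromatic carbon, ortho to a large group, gives no change at the digits printed from compound 1 to compound 3 (within the scatter) and so provides the first reading of this exchange. At this place, one heavy atom can stand in for three, and the two hydrogen-bond acceptors of nitro can go, with the dose staying within the scatter. Nothing measured here explains this result. Going by these compounds, whether an amine or a carboxylic acid at this place would also leave the dose within the scatter remains open.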